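From benzyl to isopropyl: a longer half-life expected

A few compounds are considered here, and "the series" means these few. Any claim that something is new, unique, unknown or untested is made for them only; others in the source may bear on it.

Among the measured compounds shown here, in an ADME assay on microsomes from liver (Mus musculus) for metabolic stability, read by LC-MS, using NADPH, tested at 1 uM (a lower number here means that the compound disappears faster, a higher number that the compound lasts longer), compound 2 `Cc1nc2c(N)ncnc2n1[C@@H]1O[C@H](CN(C)C/C=C\CNC(=O)OCc2ccccc2)[C@@H](O)[C@H]1O` gives 0.217 h, the only number so far. Compound 1 `CCOC(=O)NC/C=C\CN(C)C[C@H]1O[C@@H](n2c(C)nc3c(N)ncnc32)[C@H](O)[C@@H]1O` gives > 1.5 h, which is a limit of the assay and not a number. Compound 3 `Cc1nc2c(N)ncnc2n1[C@@H]1O[C@H](CN(C)C/C=C\CNC(=O)OC(C)C)[C@@H](O)[C@H]1O` carries isopropyl in place of benzyl on an oxygen next to a carbonyl group. For the measured compounds named here, one measured step bears on this, an at least 6.9-fold lower number from compound 1 to compound 2 (0.83 log units; beyond the scatter), where phenyl took the place of methyl. Compound 3 has no such ring. A rise beyond the scatter is therefore expected, a 3.7-fold higher number from compound 2 to compound 3 (0.57 log units; beyond the scatter). For compound 3 the estimated half-life is 0.8 h, with an expected range from 0.3 h to 1.5 h.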

Compound 3, half-life: > 1.5 h
Compound 3 gave a limit, no number (the forecaster's own chance of this, stated with the estimate: 30%); middle value at least 1.8-fold (0.27 log units) away from the limit.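

In this assay, isopropyl in place of benzyl on an oxygen next to a carbonyl group gives an at least 6.9-fold higher number from compound 2 to compound 3 (0.83 log units; beyond the scatter). Among the compounds shown here, with this second step, the short half-life at this position is seen only with benzyl, and neither compound 1 nor compound 3, both without the ring, shows it. The step from compound 1 to compound 3 cannot be read, and these two compounds cannot be ranked: the limit of > 1.5 h in this assay, at which 2 of the 3 values shown sit.

Still open, going by these compounds, is whether the aromatic ring itself matters or the size of the group does. Cyclohexylmethyl on the same oxygen would separate the two.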